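A few compounds are considered here, and "the series" means these few. Any claim that something is new, unique, unknown or untested is made for them only; others in the source may bear on it.

Values in a toxicity assay on CHO cells (Cricetulus griseus) for cytotoxicity, read by WST assay, with a stated time of 24 h; a higher number here means a weaker inhibitor, a lower number a stronger inhibitor:
- Compound 1 `CC(C)=CCC/C(C)=C\CCC(C)=CCNCCN`: 32300 nM
- Compound 2 `CC(C)=CCC/C(C)=C\CCC(C)=CCNCCCN1CCCC1`: 85300 nM
- Compound 3 `CC(C)=CCC/C(C)=C\CCC(C)=CCNCCCNCCCN`: 30200 nM

Compound 3 stands level with compound 1, as a 1.1-fold lower number from compound 1 to compound 3 (0.03 log units; within the scatter) shows, and clear of compound 2, as a 2.8-fold lower number from compound 2 to compound 3 (0.45 log units; beyond the scatter) shows. Compound 4 `CC(C)=CCC/C(C)=C\CCC(C)=CCNCCCN(C)CCCN` has methyl in place of hydrogen on an amine nitrogen. Going by the values given here, no measured step makes this exact change. The two steps involving the pyrrolidin-1-yl group, a 2.6-fold higher number from compound 1 to compound 2 (0.42 log units; beyond the scatter) and a 2.8-fold lower number from compound 2 to compound 3 (0.45 log units; beyond the scatter), are only modest, so little movement is expected in this assay. The expected step, a 1.3-fold higher number from compound 3 to compound 4 (0.10 log units; within the scatter), leans slightly towards a higher number and stays within the scatter. The estimate for compound 4 is 38000 nM, with an expected range of 18000 nM to 80000 nM.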

Compound 4, half-maximal inhibitory concentration: 10500 nM
The estimate for compound 4 lay 3.6-fold (0.56 log units) above the measured number; the measured number lies below the stated range.
By their numbers in this assay, from the lowest: compound 4; then compounds 3 and 1 (each within the scatter of the next); then compound 2.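

Methyl in place of hydrogen on this amine nitrogen, whose other neighbours are both saturated chain carbons, gives a 2.9-fold lower number from compound 3 to compound 4 (0.46 log units; beyond the scatter) in this assay: one added carbon moves the number beyond the scatter. Compound 4 also stands clear of the other two, with an 8.1-fold lower number from compound 2 to compound 4 (0.91 log units; beyond the scatter) and a 3.1-fold lower number from compound 1 to compound 4 (0.49 log units; beyond the scatter), and so holds the lowest number of the set. Nothing measured here accounts for this shift.

From the compounds shown here alone, whether ethyl or acetyl on this nitrogen would follow methyl remains open. So does the outcome of a longer chain in place of the 3-aminopropyl group.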